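This account rests on a few compounds, and the source may have more. Where it says the series, first, only, none or still open, it means among the compounds named here.

Among the measured compounds shown here, compound 1 `COc1cc(/C=C/C(=O)c2sc(Nc3ccc(Cl)cc3)nc2C)cc(OC)c1OC` is one of three compounds measured here. In a functional assay on Bel-7402 cells (Homo sapiens) for cytotoxicity, read by MTT assay (on this read-out lower numbers stand for stronger inhibition and higher numbers for weaker inhibition), compound 1 gives > 25000 nM, which is a limit of the assay rather than a number. Compound 2 `COc1cccc(/C=C/C(=O)c2sc(Nc3ccccc3)nc2C)c1` in this assay also gives only a limit, > 25000 nM. Compound 3 `Cc1ccc(Nc2nc(C)c(C(=O)/C=C/c3ccc(Cl)cc3)s2)cc1` in this assay likewise gives a limit, > 25000 nM. For the measured compounds named here, all three measured compounds therefore sit at the limit of > 25000 nM in this assay, at which 3 of the 3 values shown sit, so there is no step between measured compounds to show how any change in structure moves the read-out. Compound 4 `COc1cc(/C=C/C(=O)c2sc(Nc3cccc(Cl)c3)nc2C)cc(OC)c1OC` has not yet been measured; it differs from compound 1 by 3-chlorophenyl in place of 4-chlorophenyl on a nitrogen on an aromatic ring. Because compound 1 sits at > 25000 nM, compound 4 is expected to give only a limit as well, with an expected step that the limit leaves unreadable from compound 1 to compound 4 that is none beyond the scatter. The estimate for compound 4 is 30000 nM, with an expected range from 10000 nM to 100000 nM.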

Compound 4, half-maximal inhibitory concentration: 14000 nM
Compound 4: middle estimate off by 2.1-fold (0.33 log units), on the high side; measured number inside the range.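

In this assay, among the compounds shown here, compound 4 gives 14000 nM, the first real number here rather than a limit, so this position on the phenyl ring can register a change in the read-out. Putting 3-chlorophenyl in place of 4-chlorophenyl on the nitrogen gives an at least 1.7-fold lower number from compound 1 to compound 4 (0.25 log units; that floor lies within the scatter). The true size of this step stays unknown, because the other compounds give only a limit: the limit of > 25000 nM in this assay, at which 3 of the 4 values shown sit.

On these data alone, whether an amine or a carboxylic acid at this place on the ring would lower the number further remains open. So does whether 3-chlorophenyl would have a similar effect on a different core.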